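The compounds below may be only part of what the source reports. "The series", "measured", "known", "first", "only" and "open" are said of these compounds alone.

Measured in a functional assay on DU-145 cells (Homo sapiens) for inhibition, read by trypan blue exclusion, with a stated time of 96 h; on this read-out lower numbers stand for stronger inhibition of growth and higher numbers for weaker inhibition of growth:
- compound 1 `COc1ccccc1/C=C(/SCc1ccc(Cl)cc1)C(=O)c1ccc(Cl)cc1`: 1000 nM
- compound 2 `COc1ccccc1/C=C(/SCc1ccc(F)cc1)C(=O)c1ccc(Cl)cc1`: 10000 nM

Of these two, compound 2 has the higher number, 10000 nM, so it is the weaker growth inhibitor. Within the data shown here, its only neighbour is compound 1, and the link between them is a 10-fold higher number from compound 1 to compound 2 (1.00 log units; beyond the scatter). That step is beyond the scatter and comes from fluoro in place of chloro on an aromatic carbon.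

The next compound, compound 3 `O=C(/C(=C\c1ccc(Cl)cc1)SCc1ccc(F)cc1)c1ccc(Cl)cc1`, changes a different part of the molecule: 4-chlorophenyl in place of 2-methoxyphenyl on a double-bonded chain carbon bound to a double-bonded chain carbon. Among the measured compounds shown here, no measured step covers a swap at this place, so the one known step says little about its size or direction. For the measured compounds named here, it shows only that a single change can move the number by the amount seen from compound 1, at 1000 nM, to compound 2, at 10000 nM. With compound 2 at the higher end of what has been seen, a small move towards lower numbers seems the safer guess in this assay, and no step beyond the scatter is expected. The expected change is a 1.7-fold lower number from compound 2 to compound 3 (0.22 log units; within the scatter). Compound 3 is estimated at 6000 nM, with an expected range of 1000 nM to 30000 nM.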

Compound 3, concentration for 50% growth inhibition: 10000 nM
Estimate against measurement, compound 3: 1.7-fold (0.22 log units) below, within the range that was stated.
By their numbers in this assay, from the lowest: compound 1; then compounds 2 and 3 (each within the scatter of the next).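

In this assay, among these compounds, this is the first reading at this position: putting 4-chlorophenyl in place of 2-methoxyphenyl on a double-bonded chain carbon bound to a double-bonded chain carbon gives no change at the digits printed from compound 2 to compound 3 (within the scatter). The group that leaves counts one hydrogen-bond acceptor and the group that enters counts none, yet the number does not shift beyond the scatter, so in this pair the position tolerates an exchange of one aromatic group for another, unlike the fluoro for chloro step seen earlier, which gave a 10-fold higher number from compound 1 to compound 2 (1.00 log units; beyond the scatter). No measurement at hand offers an explanation for this result.

On these data alone, the pair carries the fluoro group on both sides, so whether the same swap would read alike with the chloro group of compound 1 remains open. A group of a different kind at this position, such as an amine, a carboxylic acid or a longer chain in place of the aromatic ring, could still move the number in either direction.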